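A few compounds are considered here, and "the series" means these few. Any claim that something is new, unique, unknown or untested is made for them only; others in the source may bear on it.

Measured in a functional assay on A549 cells (Homo sapiens) for cytotoxicity, read by MTT assay, with a stated time of 72 h; on this read-out higher numbers stand for weaker inhibition and lower numbers for stronger inhibition:
- compound 1 `COc1cc2ncnc(Nc3ccc(F)c(Cl)c3)c2cc1NC(=O)/C=C/c1ccccc1[N+](=O)[O-]` gives 33300 nM
- compound 2 `COc1ccc(/C=C/C(=O)Nc2cc3c(Nc4ccc(F)c(Cl)c4)ncnc3cc2OC)c(OC)c1` gives 33300 nM
- compound 3 `COc1cc2ncnc(Nc3ccc(F)c(Cl)c3)c2cc1NC(=O)/C=C/c1ccc(C#N)cc1` gives "not active" (no number reported)

Compound 3 has no place on the numeric scale, since no number was reported for it. For the measured compounds named here, its standing rests on that qualitative result alone, and no size of step can be worked out from it.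

The next compound is compound 4 `COc1cc2ncnc(Nc3ccc(F)c(Cl)c3)c2cc1NC(=O)/C=C/c1cc(OC)c(OC)c(OC)c1`, which is made from compound 3 by this change: 3,4,5-trimethoxyphenyl in place of 4-cyanophenyl on a double-bonded chain carbon bound to a double-bonded chain carbon. In words, 3,4,5-trimethoxyphenyl stands in place of 4-cyanophenyl on a double-bonded chain carbon bound to a double-bonded chain carbon.

Going by the values given here, only one measured step bears on this, as it exchanges one substituted phenyl for another at the same place. Putting 2,4-dimethoxyphenyl in place of 2-nitrophenyl gave no change at the digits printed from compound 1 to compound 2 (within the scatter). That is a single step, and compound 3 stands outside it, so the evidence is thin. The working expectation in this assay is therefore no step beyond the scatter from the level shared by compounds 1 and 2, with no direction favoured. A result without a number, as for compound 3, remains a real possibility.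

Compound 4 is expected at 30000 nM, with an estimated range from 12000 nM to 60000 nM.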

Compound 4, half-maximal inhibitory concentration: "not active" (no number reported)
The entry for compound 4 holds no number; there is nothing to compare the estimate with.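

In this assay compound 3 and compound 4 are both reported as "not active" without a number, so no step can be read between them. No measured evidence bears on this result. The compounds shown leave open whether compound 3 and compound 4 differ at all on this read-out, and where either stands relative to compound 1 and compound 2.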